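Butylsulfamoyl in Place of Pentylcarbonyl on a Shared Core

A few compounds are considered here, and "the series" means these few. Any claim that something is new, unique, unknown or untested is made for them only; others in the source may bear on it.

Of the compounds shown here, three built on one shared core have been measured in a functional assay for inhibition, with Homo sapiens as the target; on this read-out lower numbers stand for stronger inhibition and higher numbers for weaker inhibition. Compound 1 `CCCCS(=O)(=O)N[C@@H](CNC(=O)c1ccc2c(c1)C(=O)N(CCC1CCNCC1)C2)C(=O)O` gives 14 nM; 9 nM (2 entries), and the several entries of compound 1 in this assay, 14 nM; 9 nM (2 entries) shows how far repeat readings of a single compound can lie apart. Compound 2 `CCOCCS(=O)(=O)N[C@@H](CNC(=O)c1ccc2c(c1)C(=O)N(CCC1CCNCC1)C2)C(=O)O` gives 8 nM. Compound 3 `CCCCCC(=O)N[C@@H](CNC(=O)c1ccc2c(c1)C(=O)N(CCC1CCNCC1)C2)C(=O)O` gives 13 nM, which places it level with compound 2 once the usual scatter is allowed for. The step between these two, a 1.6-fold higher number from compound 2 to compound 3 (0.21 log units; within the scatter), puts pentylcarbonyl in place of (2-ethoxyethyl)sulfonyl on an amine nitrogen.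

The next compound, compound 4 `CCCCNS(=O)(=O)N[C@@H](CNC(=O)c1ccc2c(c1)C(=O)N(CCC1CCNCC1)C2)C(=O)O`, is changed at that same nitrogen, with butylsulfamoyl in place of pentylcarbonyl on an amine nitrogen. Going by the values given here, only one measured step bears on this exchange, the one that led to compound 3, and at a 1.6-fold higher number from compound 2 to compound 3 (0.21 log units; within the scatter) it did not leave the scatter. That single step is thin evidence, but it gives no reason to expect a large move in this assay, and no direction can be drawn from it. The expected change is a 1.2-fold lower number from compound 3 to compound 4 (0.07 log units; within the scatter), which amounts to no step beyond the scatter. For compound 4 the estimate is 11 nM, with an expected range of 5 nM to 25 nM.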

Compound 4, half-maximal inhibitory concentration: 19 nM
The estimate for compound 4 lay 1.7-fold (0.24 log units) below the measured number; the range from low to high includes it.
By their numbers in this assay, from the lowest: compounds 2, 3 and 4 (each within the scatter of the next, the first and the last beyond it).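

In this assay, the exchange at the amine nitrogen now covers a third kind of group, and a 1.5-fold higher number from compound 3 to compound 4 (0.16 log units; within the scatter) stays inside the scatter, so butylsulfamoyl and pentylcarbonyl cannot be told apart at this position. Read at the sulfonyl sulfur, the same compound gives the first step in the series to leave the scatter, a modest one with butylamino in place of 2-ethoxyethyl: a 2.4-fold higher number from compound 2 to compound 4 (0.38 log units; beyond the scatter). Repeat readings of a single compound set the measure against which so modest a step has to be weighed: the several entries of compound 1 in this assay, 14 nM; 9 nM (2 entries)

The compounds shown leave open whether the gap at the sulfonyl sulfur follows the added amino nitrogen or the chain itself, a question that a 2-ethoxyethylamino group on the sulfur would bear on directly. They also leave open how a methyl or a phenyl in place of the butyl on the sulfamoyl nitrogen would read, and whether an ester in place of the carboxylic acid would hold the number in this range.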